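Four quinol-bearing sulfonamides: from ester to acid

The source may report more compounds than this note shows. Statements on the series, on what has been measured and on what is new or still open speak of the compounds shown alone.

Values in a functional assay on A549 cells (Homo sapiens) for inhibition, read by MTT assay, with a stated time of 72 h; on this read-out lower numbers stand for stronger inhibition and higher numbers for weaker inhibition:
- compound 1 `O=C1C=CC(O)(c2cc3ccccc3n2S(=O)(=O)c2ccccc2)C=C1`: 500 nM
- compound 2 `COC(=O)CCc1ccc(S(=O)(=O)n2c(C3(O)C=CC(=O)C=C3)cc3ccccc32)cc1`: 500 nM
- compound 3 `COC(=O)CCc1ccc(S(=O)(=O)n2c(C3(O)C=CC(=O)C=C3)cc3ccc(F)cc32)cc1`: 500 nM

Compound 1 and compound 2 stand level with compound 3 at 500 nM. Compound 4 `O=C1C=CC(O)(c2cc3ccc(F)cc3n2S(=O)(=O)c2ccc(CCC(=O)O)cc2)C=C1` differs from compound 3 by a single change: hydrogen in place of methyl on an oxygen next to a carbonyl group. In words, this is hydrogen in place of methyl on an oxygen next to a carbonyl group, so methoxycarbonyl becomes carboxy.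

The measured steps bear on this only indirectly. Adding 2-(methoxycarbonyl)ethyl gave no change at the digits printed from compound 1 to compound 2 (within the scatter), and adding fluoro gave no change at the digits printed from compound 2 to compound 3 (within the scatter). Among the compounds with values here, neither step alters methoxycarbonyl itself, and no measured compound carries carboxy, so the direction remains open. The step of a 1.4-fold higher number from compound 3 to compound 4 (0.15 log units; within the scatter) is expected to stay small in this assay. The estimate for compound 4 is 700 nM, with an expected range of 300 nM to 3000 nM.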

Compound 4, half-maximal inhibitory concentration: 500 nM
Compound 4: middle estimate off by 1.4-fold (0.15 log units), on the high side; low and high end bracket the measured number.
By their numbers in this assay, from the lowest: compounds 1, 2, 3 and 4 (each within the scatter of the next).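

Turning methoxycarbonyl into carboxy brings no change at the digits printed from compound 3 to compound 4 (within the scatter) in this assay, so the number stays level whether this chain ends in the ester or the free acid. This is the first compound shown with carboxy, and it extends the flat picture from the earlier steps to a change at the end of the chain. Nothing measured here offers an explanation for this result.

As far as these compounds go, whether an amine or a primary amide at the same chain end would also stay level remains open. So does the effect of a longer chain, or of carboxy on a compound without the fluoro group.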